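Compound 1 to compound 4: a nitro step

The source may hold more compounds than are shown below. What is called first, only, known or untested is meant among the compounds shown, and "the series" means these compounds.

compound 1 `COc1cc(OC)c(OC)cc1/C=C/C(=O)c1ccccc1`: > 150000 nM
compound 2 `COc1cc(OC)c(OC)cc1/C=C/C(=O)c1cc(Cl)ccc1O`: > 150000 nM
compound 3 `COc1cc(OC)c(OC)cc1/C=C/C(=O)c1cccc(C(F)(F)F)c1`: > 150000 nM

In a functional assay on SW982 cells (Homo sapiens) for inhibition, read by MTT assay, with a stated time of 72 h (on this read-out higher numbers stand for weaker inhibition and lower numbers for stronger inhibition), compound 1 gives > 150000 nM, which is a limit and not a number. The other two compounds offer no firmer footing, and the whole set shares one mark: the limit of > 150000 nM in this assay, at which 3 of the 3 values shown sit.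

Compound 4 `COc1cc(OC)c(OC)cc1/C=C/C(=O)c1ccc([N+](=O)[O-])cc1` has not yet been measured. It differs from compound 1 by a single change, (nitro in place of hydrogen on an aromatic carbon), with nitro in place of hydrogen on an aromatic carbon, para to a large group.

Among the measured compounds shown here, two measured steps bear on this. The closer is a step that the two limits leave unreadable from compound 1 to compound 3, where trifluoromethyl also replaces hydrogen on an aromatic carbon. The other is a step that the two limits leave unreadable from compound 1 to compound 2, where 5-chloro-2-hydroxyphenyl replaces phenyl on a carbonyl carbon. Neither step has a readable size, so neither gives a direction to carry over to the nitro change. The most likely outcome in this assay is therefore another limit, with no clear shift in either direction.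

The expected step is a step that the limit leaves unreadable from compound 1 to compound 4, and this expectation is a loose one. For compound 4 the estimated value is 180000 nM, with an expected range from 60000 nM to 400000 nM.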

Compound 4, half-maximal inhibitory concentration: > 150000 nM
Compound 4 ended at the assay's limit; the forecaster's own chance of this, stated with the estimate: 75%; the middle value does not contradict the limit.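

Compound 4 gives > 150000 nM in this assay, which is a limit and not a number. No new step can be read between compound 1 and compound 4, and the whole set stays at one mark: the limit of > 150000 nM in this assay, at which 4 of the 4 values shown sit.

The compounds shown leave open how far any of these changes moves inhibition, and which change to the shared core would give a measurable value.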